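Notes on the bis(diazeniumdiolate) dinitrophenyl ether series

The source may report more compounds than this note shows. Statements on the series, on what has been measured and on what is new or still open speak of the compounds shown alone.

Going by the values given here, compound 3 `CCOC(=O)N1CCN(/[N+]([O-])=N/Oc2cc(O/N=[N+](\[O-])N3CCN(C(=O)N(CC)CC)CC3)c([N+](=O)[O-])cc2[N+](=O)[O-])CC1` carries a 4-(ethoxycarbonyl)piperazin-1-yl group on each double-bonded nitrogen and gives 900 nM in a functional assay on HL-60 cells (Homo sapiens) for antiproliferative activity, read by MTT assay, with a stated time of 72 h (on this read-out higher numbers stand for weaker inhibition and lower numbers for stronger inhibition), the lowest of the three numbers measured so far. Compound 1 `CCN(CC)C(=O)N1CCN(/[N+]([O-])=N/Oc2cc(O/N=[N+](\[O-])N(C)C)c([N+](=O)[O-])cc2[N+](=O)[O-])CC1` gives 1900 nM in this assay, and compound 2 `CCOC(=O)N1CCN(/[N+]([O-])=N/Oc2cc(O/N=[N+](\[O-])N(CC)CC)c([N+](=O)[O-])cc2[N+](=O)[O-])CC1` gives 2100 nM.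

Compound 4 `CCN(CC)C(=O)N1CCN(/[N+]([O-])=N/Oc2cc(O/N=[N+](\[O-])N(CC)CC)c([N+](=O)[O-])cc2[N+](=O)[O-])CC1` differs from compound 3 in one place: diethylamino in place of 4-(ethoxycarbonyl)piperazin-1-yl on a double-bonded nitrogen. Among the compounds with values here, the only measured step that touches this position is a 2.1-fold lower number from compound 1 to compound 3 (0.32 log units; beyond the scatter), where a 4-(ethoxycarbonyl)piperazin-1-yl group replaced a dimethylamino group. The step to compound 4 runs the other way, from the same piperazinyl group back to a small dialkylamino group, and compound 2, which already carries diethylamino on a double-bonded nitrogen, sits close to compound 1. The expectation is therefore a step back upward of about the same size as the one seen, so compound 4 is expected to land near compound 1 and compound 2, a step of a 2.0-fold higher number from compound 3 to compound 4 (0.30 log units; within the scatter).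

Compound 4 is estimated at 1800 nM in this assay, with a range from 900 nM to 3600 nM.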

Compound 4, half-maximal inhibitory concentration: 2900 nM
Estimate against measurement, compound 4: 1.6-fold (0.21 log units) below; measured number inside the range.
By their numbers in this assay, from the lowest: compound 3; then compounds 1, 2 and 4 (each within the scatter of the next).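

In this assay, exchanging 4-(ethoxycarbonyl)piperazin-1-yl for diethylamino on a double-bonded nitrogen gives a 3.2-fold higher number from compound 3 to compound 4 (0.51 log units; beyond the scatter) and so confirms, from a second compound, that the upward move is beyond the scatter; compound 3 alone of the four holds no small dialkylamino group on either double-bonded nitrogen. The other two changes do not separate the compounds: diethylamino in place of dimethylamino on a double-bonded nitrogen gives a 1.5-fold higher number from compound 1 to compound 4 (0.18 log units; within the scatter) and diethylamino in place of ethoxy on a carbonyl carbon gives a 1.4-fold higher number from compound 2 to compound 4 (0.14 log units; within the scatter) and both stay within the scatter. Nothing measured here explains why the piperazinyl group on this nitrogen goes with the lower number.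

As far as these compounds go, it remains open whether the ring alone carries the difference or the ethoxycarbonyl group on it is also needed, which a plain piperazin-1-yl group, a morpholin-4-yl group or a carboxylic acid in place of the ethyl ester on this nitrogen would test. From the compounds shown here alone, it is also open whether a longer chain such as dipropylamino would stay level with diethylamino and dimethylamino.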